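The source may report more compounds than this note shows. Statements on the series, on what has been measured and on what is new or still open speak of the compounds shown alone.

Measured in an assay on membranes from heart (Canis lupus familiaris) for displacement of a labelled ligand from sulfonylurea receptor 2, Kir6.2 (Homo sapiens); a lower number here means a stronger inhibitor, a higher number a weaker inhibitor:
Compound 1, `CC(/N=C(\NC#N)Nc1cccc(C#N)c1)C(C)(C)C`, gives 350 nM.
Compound 3, `CC(C)(C)/N=C(\NC#N)Nc1ccc(C#N)cc1`, gives 480 nM.
Compound 2, `CCC(C)(C)/N=C(\NC#N)Nc1ccc(S(=O)(=O)N2CCCCC2)cc1`, reaches only a limit of the assay, > 30000 nM.

Compound 1 holds the lowest of the two numbers in this assay; compound 3 stands nearest, with a number higher than that of compound 1 but within the usual scatter, so no order between the two can be claimed. The value of compound 2 is a limit and not a number: compound 2 sits at the limit of > 30000 nM in this assay, at which 1 of the 3 values shown sits.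

Compound 4, `CC(/N=C(\NC#N)Nc1ccccc1)C(C)(C)C`, has not yet been measured in this assay. It differs from compound 1 in one place: hydrogen in place of cyano on an aromatic carbon. Going by the values given here, no step between two measured compounds isolates this change, so its size cannot be read from the data. Among the compounds with values here, compound 1 and compound 3 both carry a cyano group and both sit in the same region of numbers; a compound without that group has no measured counterpart here. Compound 4 is expected to come out somewhat weaker than compound 1, with an expected step of a 2.9-fold higher number from compound 1 to compound 4 (0.46 log units; beyond the scatter) in this assay, modest but beyond the scatter. The estimate for compound 4 is 1000 nM, with a range from 300 nM to 4000 nM.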

Compound 4, inhibition constant: 680 nM
Estimate against measurement, compound 4: 1.5-fold (0.17 log units) above, within the range that was stated.
By their numbers in this assay, from the lowest: compounds 1, 3 and 4 (each within the scatter of the next). At a limit, above all of these: compound 2.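

In this assay, replacing cyano with hydrogen on this aromatic carbon can now be read directly as a single change, and it gives a 1.9-fold higher number from compound 1 to compound 4 (0.29 log units; within the scatter). Going by these compounds alone, no earlier pair isolated this change, and the step now shows that the number remains in the same region without the cyano group, so the data do not show that this group is needed at this place for a value of this order. Nothing measured here offers a reason for the size of this step.

The compounds shown leave open whether another group on this same carbon, such as an amine, a carboxylic acid or a methoxy group, would move the number beyond the scatter. This one step also covers only one place and one version of the shared core, so it cannot say whether swapping cyano for hydrogen would read the same at another carbon of the ring or alongside a different alkyl chain.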